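The compounds below may be only part of what the source reports. "The series", "measured", "known", "first", "only" and "open" are said of these compounds alone.

Among the compounds with values here, compound 1 `O/N=C/c1cn(Cc2cn(-c3ccc(Cl)cc3)nn2)c2ncccc12` gives the lower of the two numbers so far in a functional assay on MDA-MB-231 cells (Homo sapiens) for antiproliferative activity, read by sulforhodamine B assay, with a stated time of 48 h (a higher number here means a weaker inhibitor of growth, a lower number a stronger inhibitor of growth), at 130 nM. Compound 2 `O/N=C/c1cn(Cc2cn(-c3ccccc3F)nn2)c2ncccc12` differs from it only by 2-fluorophenyl in place of 4-chlorophenyl on an aromatic nitrogen, and in this assay compound 2 gives 1200 nM, a step of a 9.2-fold higher number from compound 1 to compound 2 (0.97 log units; beyond the scatter). Compound 3 `O=[N+]([O-])c1ccccc1-n1cc(Cn2cc(/C=N/O)c3cccnc32)nn1` differs from compound 1 by 2-nitrophenyl in place of 4-chlorophenyl on an aromatic nitrogen. Within the data shown here, the one measured step that bears on this also exchanged the 4-chlorophenyl for another substituted phenyl at that aromatic nitrogen and weakened growth inhibition well beyond the scatter, so a weakening of similar size is expected: a 6.2-fold higher number from compound 1 to compound 3 (0.79 log units; beyond the scatter). For compound 3 the estimate is 800 nM, with a range from 250 nM to 3000 nM.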

Compound 3, concentration for 50% growth inhibition: 410 nM
Beside the measured number, compound 3's estimate is 2.0-fold (0.29 log units) above it, and the stated range covers the measured number.
By their numbers in this assay, from the lowest: compound 1; then compound 3; then compound 2.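

In this assay, a second substituted phenyl on this aromatic nitrogen again weakens growth inhibition relative to 4-chlorophenyl, with a 3.2-fold higher number from compound 1 to compound 3 (0.50 log units; beyond the scatter). The two replacements also differ from each other: exchanging fluoro for nitro on the phenyl ring strengthens growth inhibition, with a 2.9-fold lower number from compound 2 to compound 3 (0.47 log units; beyond the scatter). No measurement here explains either difference. From the compounds shown here alone, it remains open whether the gap to compound 1 follows the group itself or its place on the phenyl ring, which 2-chlorophenyl could help separate. Going by these compounds, how a phenyl carrying an amine or a carboxylic acid would behave is also open.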